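Iodophenyl replacing cyanophenyl on the dihydropyridine series

The source may report more compounds than this note shows. Statements on the series, on what has been measured and on what is new or still open speak of the compounds shown alone.

Of the compounds shown here, three of the shared core have numbers so far. In a functional assay (muscle tissue) with Cavia porcellus as the target (on this read-out higher numbers stand for an effect only at larger amounts of compound and lower numbers for an effect already at smaller amounts), compound 2 `COC(=O)C1=C(C)N=C(C)/C(=C(\O)OC)C1c1ccccc1C#N` gives 15.9 nM, the lowest of the three, and its gaps to both others lie beyond the scatter. Compound 3 `COC(=O)C1=C(C)N=C(C)/C(=C(\O)OC)C1c1cc([N+](=O)[O-])ccc1O` gives 100 nM in this assay, the nearest neighbour. Compound 1 `COC(=O)C1=C(C)N=C(C)/C(=C(\O)OC)C1c1cc(OC)c(OC)cc1OC` gives 1000000 nM in this assay, far from both.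

Compound 4 `COC(=O)C1=C(C)N=C(C)/C(=C(\O)OC)C1c1cccc(I)c1` has not yet been run in this assay. It differs from compound 2 in one place: 3-iodophenyl in place of 2-cyanophenyl on a saturated ring carbon. Among the measured compounds shown here, no measured pair shows this exchange, so there is no step to lean on; only the three values above frame the outcome. Since compound 2 sits at 15.9 nM and only compound 1 falls out of the active range altogether, the expectation is a step of small size from compound 2 to compound 4, in no clear direction beyond the scatter, amounting to a 1.3-fold higher number from compound 2 to compound 4 (0.10 log units; within the scatter). Compound 4 is accordingly estimated at 20 nM, with a range from 4 nM to 100 nM.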

Compound 4, half-maximal effective concentration: 41.7 nM
Estimate against measurement, compound 4: 2.1-fold (0.32 log units) below, within the range that was stated.
By their numbers in this assay, from the lowest: compound 2; then compound 4; then compound 3; then compound 1.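

Among the compounds shown here, the step of a 2.6-fold higher number from compound 2 to compound 4 (0.42 log units; beyond the scatter) in this assay is the first one-place comparison, and it is modest in size. Activity therefore does not depend on the nitrile or on the hydrogen-bond acceptor of 2-cyanophenyl, since 3-iodophenyl has neither and compound 4 still gives 41.7 nM. The compounds shown offer nothing that accounts for the step.

The exchange changes both the group and its place on the phenyl ring, so the two contributions remain unseparated; 2-iodophenyl or 3-cyanophenyl would divide them. Also open, going by these compounds, is how this position responds to other kinds of group on the phenyl ring, such as an amine or a carboxylic acid, and whether any group here gives a lower number than the nitrile of compound 2.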